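Adding a Methoxybenzyl Arm to a Weak Cytotoxic Amidine

This account rests on a few compounds, and the source may have more. Where it says the series, first, only, none or still open, it means among the compounds named here.

Among the measured compounds shown here, compound 2 (`Cn1nc(-c2ccccc2)c2cc(C(=N)Nc3cccc(C(F)(F)F)c3)ncc21`) is the only compound with a number: in a functional assay on PC-3 cells (Homo sapiens) for cytotoxicity, read by MTT assay, with a stated time of 72 h (on this read-out lower numbers stand for stronger inhibition and higher numbers for weaker inhibition), compound 2 gives 20900 nM, a weak result. Compound 1 (`COc1ccc(Cn2nc(-c3ccccc3)c3cc(C(=N)Nc4cccc(C(F)(F)F)c4)nc(NC4CCCCC4)c32)cc1`) shares the benzyl substituent but in this assay reads "not determined" (no result reported). Compound 3 (`COc1ccc(Cn2nc(-c3ccccc3)c3cc(C(=N)Nc4cccc(C(F)(F)F)c4)ncc32)cc1`) differs from compound 2 by 4-methoxyphenyl in place of hydrogen on a saturated chain carbon bound to an aromatic nitrogen. For the measured compounds named here, no measured step covers this change, so only a modest shift is expected, perhaps a small gain that may not clear the scatter. Compound 3 is expected to reach 10000 nM, within 3000 nM to 40000 nM, a step of a 2.1-fold lower number from compound 2 to compound 3 (0.32 log units; beyond the scatter).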

Compound 3, half-maximal inhibitory concentration: > 50000 nM
Compound 3 gave a limit, no number (the forecaster's own chance of this, stated with the estimate: 10%); at least 5.0-fold (0.69 log units) between middle value and limit.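

In this assay compound 3 gives > 50000 nM, which is a limit of the assay and not a number. Putting 4-methoxyphenyl in place of hydrogen on a saturated chain carbon bound to an aromatic nitrogen therefore brings no gain here, but a loss: an at least 2.3-fold higher number from compound 2 to compound 3 (0.37 log units; beyond the scatter). The full size of this step stays unknown because it rests on a limit: the limit of > 50000 nM in this assay, at which 1 of the 3 values shown sits.

On these data alone, whether a plain benzyl without the methoxy, or a carboxylic acid on that chain, would read differently from compound 2 stays open. So does the effect of the cyclohexylamino group of compound 1 on this arm.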